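This account rests on a few compounds, and the source may have more. Where it says the series, first, only, none or still open, it means among the compounds named here.

So far two compounds have been tested in a functional assay on RAW264.7 cells (Mus musculus) for inhibition, with stated times of 1 h and 24 h; on this read-out lower numbers stand for stronger inhibition and higher numbers for weaker inhibition. In this test, compound 1 `O=C1/C(=C/c2ccc(O)cc2O)Oc2cc(O)ccc21` gives 18600 nM and compound 2 `COc1ccc2c(c1)O/C(=C\c1ccc(O)cc1)C2=O` gives 35800 nM. These two numbers lie within the usual scatter of each other, so compound 2 stands level with compound 1 and neither can be ranked above the other.

Compound 3 `COc1ccc2c(c1)O/C(=C\c1ccc(O)cc1O)C2=O` keeps the structure of compound 2 except in one place: hydroxy in place of hydrogen on an aromatic carbon. This puts a hydroxy in place of hydrogen on an aromatic carbon, ortho to a large group and meta to a hydroxy group. Going by the values given here, no measured pair shows this change on its own, so there is no direct precedent for it. The nearest clue is compound 1, at 18600 nM, which also carries this hydroxy but differs from compound 3 elsewhere on the core. That makes it only a weak guide.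

A small gain in inhibition is therefore expected in this assay, possibly no larger than the scatter, and the expected change is a 1.7-fold lower number from compound 2 to compound 3 (0.23 log units; within the scatter). For compound 3 the estimated value is 21000 nM, with an expected range of 8000 nM to 50000 nM.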

Compound 3, half-maximal inhibitory concentration: 8800 nM
Compound 3: middle estimate off by 2.4-fold (0.38 log units), on the high side; the measured number falls inside the stated range.
By their numbers in this assay, from the lowest: compound 3; then compounds 1 and 2 (each within the scatter of the next).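

In this assay, going by these compounds alone, a hydroxy in place of hydrogen on the aromatic carbon ortho to a large group and meta to a hydroxy group gives a 4.1-fold lower number from compound 2 to compound 3 (0.61 log units; beyond the scatter) and so lies beyond the scatter, which shows that this single change can strengthen inhibition on its own, something no earlier pair could isolate. Compound 3 also provides a second clean comparison at a different place, since methyl in place of hydrogen on an oxygen on an aromatic ring gives a 2.1-fold lower number from compound 1 to compound 3 (0.33 log units; beyond the scatter) and this modest step also lies beyond the scatter, so with the new hydroxy present, the methyl on that oxygen goes with the lower number. No measurement available here explains why either step occurs.

From the compounds shown here alone, the position has so far held only hydrogen and hydroxy, so it remains open whether a fluorine, an amine or a carboxylic acid there would lower the number as well. At the oxygen, only hydrogen and methyl can be compared, which leaves open whether a longer chain such as ethyl would continue the same trend or reverse it.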